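The source may report more compounds than this note shows. Statements on the series, on what has been measured and on what is new or still open speak of the compounds shown alone.

Measured so far:
compound 1, `O/N=C(\CCN1CCN(c2ccccn2)CC1)c1ccc(F)cc1F`: 8.9 nM
compound 2, `Cc1ccc(OCc2ccccc2)c(/C(CCN2CCN(c3ccccn3)CC2)=N/O)c1`: > 10000 nM

The series is followed in a functional assay on HEK293 cells with D(4) dopamine receptor (Homo sapiens) as the target, read by FLIPR; on this read-out higher numbers stand for an effect only at larger amounts of compound and lower numbers for an effect already at smaller amounts. In this assay compound 1 gives 8.9 nM. For compound 2 the assay reports no number, only the limit > 10000 nM. Compound 2 therefore stands at the limit of > 10000 nM in this assay, at which 1 of the 2 values shown sits, so its own position on the scale is not known beyond that limit, and the gap between compound 1 and compound 2 can only be read as compound 1 sitting well inside the measurable range while compound 2 does not.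

The next compound is compound 3, `Cc1ccc(O)c(/C(CCN2CCN(c3ccccn3)CC2)=N/O)c1`. It is compound 2 with the change (hydrogen in place of benzyl on an oxygen on an aromatic ring); the same difference, cut one bond further out, reads benzyloxy to hydroxy. Among the measured compounds shown here, no step between two measured compounds is available here, so the size of this change cannot be read from the data. A move back into the measurable range is nonetheless expected, with the step estimated as an at least 16-fold lower number from compound 2 to compound 3 (1.22 log units; beyond the scatter), toward an effect at smaller amounts of compound. For compound 3 the estimate is 600 nM, with a range of 60 nM to 6000 nM.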

Compound 3, half-maximal effective concentration: 19.2 nM
Compound 3: middle estimate off by 31-fold (1.49 log units), on the high side; the measured number lies below the stated range.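

On the oxygen on the aromatic ring, the change from benzyloxy to hydroxy decides whether this assay returns a number at all, with the step reading an at least 520-fold lower number from compound 2 to compound 3 (2.71 log units; beyond the scatter). Compound 2 stands at a limit and not at a number, so this step has no fixed size: the limit of > 10000 nM in this assay, at which 1 of the 3 values shown sits.

With hydrogen on that oxygen, the aromatic group on the carbon with a double bond to nitrogen can vary at a much smaller cost, as 2-hydroxy-5-methylphenyl in place of 2,4-difluorophenyl gives only a 2.2-fold higher number from compound 1 to compound 3 (0.33 log units; beyond the scatter), so a measurable effect at low amounts of compound is seen with both of these groups.

Still open, from the compounds shown here alone, is whether the loss belongs to benzyl in particular or to any group larger than hydrogen on that oxygen, a question that a methoxy group at the same place would help to settle. Also open, going by these compounds, is how the hydroxy and the methyl of the 2-hydroxy-5-methylphenyl group each contribute to the modest step, as they enter together and the values shown cannot separate them.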